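This account rests on a few compounds, and the source may have more. Where it says the series, first, only, none or still open, it means among the compounds named here.

The study follows a series built on the shared core of compound 1, `C=CCOc1cc(C2=C(c3cc(OC)c(OC)c(OC)c3)C(=O)C(O)C2)ccc1OC`, whose cytotoxicity was read in an ADME assay on PA-1 cells (Homo sapiens) for cytotoxicity, read by MTT assay, with a stated time of 72 h; a higher number here means a weaker inhibitor, a lower number a stronger inhibitor. Compound 1 sits at the limit of the assay, giving > 100 ug/mL, so only a limit and no number is known for it; the limit of > 100 ug/mL in this assay, at which 1 of the 3 values shown sits, marks where it stands among the three values shown. Compound 2, `COc1ccc(C2=C(c3cc(OC)c(OC)c(OC)c3)CC(O)C2=O)cc1N`, gives 20 ug/mL in this assay. Compound 3, `COc1ccc(C2=C(c3cc(OC)c(OC)c(OC)c3)C(=O)CC2O)cc1`, gives 3.38 ug/mL in this assay, which is the lowest of the three numbers shown.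

The next compound, compound 4, `COc1ccc(C2=C(c3cc(OC)c(OC)c(OC)c3)C(=O)C(O)C2)cc1`, has not yet been measured. It differs from compound 1 by hydrogen in place of allyloxy on an aromatic carbon, ortho to a methoxy group. For the measured compounds named here, no measured step of this kind is available, so the size of the change can only be expected. Since compound 1 gives only a limit of > 100 ug/mL, the step of an at least 8.3-fold lower number from compound 1 to compound 4 (0.92 log units; beyond the scatter) is expected to move toward stronger inhibition, by more than the usual scatter. Compound 4 is therefore expected to give about 12 ug/mL, with a range from 2.5 ug/mL to 60 ug/mL, in this assay.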

Compound 4, half-maximal inhibitory concentration: < 1 ug/mL
Compound 4: a limit, no number; the forecaster's own chance of this, stated with the estimate: 15%; middle value at least 12-fold (1.07 log units) from the limit.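

In this assay, the exchange of allyloxy for hydrogen on the aromatic carbon ortho to a methoxy group gives an at least 100-fold lower number from compound 1 to compound 4 (2.00 log units; beyond the scatter), the only single-change step shown and a large one, which makes this position highly sensitive to the group it carries. Compound 1 stands at a limit of the assay, not at a number: the limit of > 100 ug/mL in this assay, at which 1 of the 4 values shown sits. Compound 4 also stands at a limit of the assay, so the step gives only a minimum size: the limit of < 1 ug/mL in this assay, at which 1 of the 4 values shown sits.

As far as these compounds go, the full size of the step remains open, as does whether the loss of the whole allyloxy group or of its double bond alone accounts for it. From the compounds shown here alone, it also remains open what a propoxy chain or a hydroxyl group would give at this place on the shared core.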